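This account rests on a few compounds, and the source may have more. Where it says the series, first, only, none or still open, it means among the compounds named here.

Measured in a functional assay on Jurkat cells (Homo sapiens) for cytotoxicity, read by luminescence and CellTiter-Glo, with a stated time of 3 days; a higher number here means a weaker inhibitor, a lower number a stronger inhibitor:
- compound 1 `O=C(Nc1cc(C(F)(F)F)cc(C(F)(F)F)c1)c1ccc(Br)cc1O`: 930 nM
- compound 2 `Cc1cc(C#N)ccc1NC(=O)c1ccc2cccnc2c1O`: 270 nM

Compound 2 has the lower of the two numbers, and its gap to compound 1 lies beyond the usual scatter of repeat measurements. Compound 3 `N#Cc1ccc(NC(=O)c2ccc3cccnc3c2O)c(C#N)c1` is the next to be tested. It differs from compound 2 by cyano in place of methyl on an aromatic carbon, with cyano in place of methyl on an aromatic carbon. Going by the values given here, no measured pair shows this change, so the expectation is only a guess, and no step beyond the scatter is expected in this assay. The expected step is a 1.1-fold higher number from compound 2 to compound 3 (0.05 log units; within the scatter). Compound 3 is estimated at 300 nM, within an expected range of 100 nM to 900 nM.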

Compound 3, half-maximal inhibitory concentration: 270 nM
For compound 3 the middle estimate is 1.1-fold (0.05 log units) above the measured one; the range from low to high includes it.
By their numbers in this assay, from the lowest: compounds 2 and 3 (each within the scatter of the next); then compound 1.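

In this assay, cyano in place of methyl on this aromatic carbon, ortho to a large group, brings no change at the digits printed from compound 2 to compound 3 (within the scatter). Going by these compounds alone, this is the first comparison that isolates a single position, since compound 1 differs from compound 2 in more than one place, and here the number is insensitive to this one swap. Nothing measured here bears on the reason for this result.

Going by these compounds, whether an amine, a carboxylic acid or a longer chain at this position would also leave the number in place remains open. So does whether the same swap would behave alike on the core of compound 1.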